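The compounds below may be only part of what the source reports. "The series", "measured", "known", "first", "only" and "open" are said of these compounds alone.

Compound 1, `C/C(=C\CC/C(C)=C/CC[C@@H]1[C@@]2(C)CCC(=O)C(C)(C)[C@H]2CC[C@@]1(C)O)CC/C=C(\C)C(=O)OCc1cn(-c2ccccc2[N+](=O)[O-])nn1`, gives only a limit in an ADME assay on L132 cells (Homo sapiens) for cytotoxicity, read by MTT assay, with a stated time of 48 h; on this read-out higher numbers stand for weaker inhibition and lower numbers for stronger inhibition: > 150000 nM.
Compound 2, `C/C(=C\CC/C(C)=C/CC[C@@H]1[C@@]2(C)CCC(=O)C(C)(C)[C@H]2CC[C@@]1(C)O)CC/C=C(\C)C(=O)OCc1cn(-c2cccc(C)c2)nn1`, also gives only a limit in this assay: > 150000 nM.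
Compound 3, `C/C(=C\CC/C(C)=C/CC[C@@H]1[C@@]2(C)CCC(=O)C(C)(C)[C@H]2CC[C@@]1(C)O)CC/C=C(\C)C(=O)OCc1cn(C[C@@H]2O[C@H](n3ccc(=O)[nH]c3=O)[C@H]3OC(C)(C)O[C@H]32)nn1`, likewise gives only a limit in this assay: > 150000 nM.

Compound 1 therefore stands nowhere on a numbered scale: it sits at the limit of > 150000 nM in this assay, at which 3 of the 3 values shown sit, together with every other measured compound. The new compound 4, `C/C(=C\CC/C(C)=C/CC[C@@H]1[C@@]2(C)CCC(=O)C(C)(C)[C@H]2CC[C@@]1(C)O)CC/C=C(\C)C(=O)OCc1cn(-c2ccccc2Cl)nn1`, differs from compound 1 in one place: chloro in place of nitro on an aromatic carbon. Within the data shown here, the only measured step with a single change is a step that the two limits leave unreadable from compound 1 to compound 2, and it concerns the aromatic nitrogen rather than the aromatic carbon changed here. Among the measured compounds shown here, no measured step gives any direction or size for the present change, so the expectation is simply that compound 4 behaves like the rest in this assay and remains at the limit, which corresponds to an expected step that the limit leaves unreadable from compound 1 to compound 4. Compound 4 is estimated at 200000 nM, between 100000 nM and 500000 nM, most probably reported again as a limit.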

Compound 4, half-maximal inhibitory concentration: > 150000 nM
Compound 4: no number, only a limit (the forecaster's own chance of this, stated with the estimate: 85%); the middle value does not contradict the limit.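

In this assay compound 4 gives > 150000 nM as a limit and not a number. The steps to compound 4 from compound 1 and from compound 2 therefore cannot be read. The compounds shown leave open how far past this limit each one lies, and whether any change would give a measurable value.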